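Bromo for hydrogen and cytotoxicity across two cores

The compounds below may be only part of what the source reports. "The series", "measured", "known", "first", "only" and "open" are said of these compounds alone.

Compound 1 `Cc1cc(S(N)(=O)=O)ccc1NC(=O)COc1ccc(Cl)cc1Oc1ccc2ccccc2c1` and compound 2 `Cc1cc(S(N)(=O)=O)ccc1NC(=O)COc1ccc(Cl)cc1Oc1ccc2ccccc2c1Br` share one core. The change between them is bromo in place of hydrogen on an aromatic carbon. In an ADME assay on C8166 cells (Homo sapiens) for cytotoxicity, read by MTT assay (on this read-out higher numbers stand for lower toxicity in this test and lower numbers for higher toxicity in this test), compound 1 gives 119000 nM. In the same this assay compound 2 gives 48100 nM. The recorded step is a 2.5-fold lower number from compound 1 to compound 2 (0.39 log units; beyond the scatter).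

Compound 3 `Cc1cc(S(N)(=O)=O)ccc1NC(=O)COc1ccc(F)cc1Oc1ccc2cc(C#N)ccc2c1` rests on a second core; the difference between the core of compound 1 and the core of compound 3 is not broken down here. In this assay compound 3 returns only a limit, > 395000 nM. This is the limit of > 395000 nM in this assay, at which 1 of the 3 values shown sits, so no number is known for compound 3, only that it lies at the limit.

Compound 4 `Cc1cc(S(N)(=O)=O)ccc1NC(=O)COc1ccc(F)cc1Oc1ccc2cc(C#N)ccc2c1Br` is the unmeasured partner of compound 3 and carries bromo in place of hydrogen on an aromatic carbon. The place of the change is the same, word for word, as in the pair of compound 1 and compound 2, so the change is the same one, made on the second core.

For compound 4 in this assay the expected step from its partner is an at least 1.5-fold lower number from compound 3 to compound 4 (0.19 log units; that floor lies within the scatter), set beside a 2.5-fold lower number from compound 1 to compound 2 (0.39 log units; beyond the scatter) and read from that earlier pair; since compound 3 sits at a limit, the starting point itself is uncertain and the range is kept wide. The estimate for compound 4 in this assay is 250000 nM, between 120000 nM and 600000 nM.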

Compound 4, half-maximal cytotoxic concentration: 35300 nM
Compound 4: the middle estimate sits 7.1-fold (0.85 log units) above what was measured; measured number below the stated range.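

In this assay, bromo in place of hydrogen on an aromatic carbon gives a lower number on both cores, which means higher toxicity in this test each time, so the direction carries from one core to the other, but the size of the step does not: the same change on two cores in this assay, a 2.5-fold lower number (0.39 log units; beyond the scatter) from compound 1 to compound 2 and an at least 11-fold lower number (1.04 log units; beyond the scatter) from compound 3 to compound 4, at least 4.5-fold (0.65 log units) apart, beyond the scatter of two such steps. On the second core the new step is an at least 11-fold lower number from compound 3 to compound 4 (1.04 log units; beyond the scatter), and this figure is a floor, not a measured size. On these data alone, compound 3 is known only through a limit of the assay, > 395000 nM, so the full size of that step stays unknown and the two cores show a difference in size without showing which feature of the second core goes with it: the limit of > 395000 nM in this assay, at which 1 of the 4 values shown sits.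

The compounds shown leave open whether a chloro, a methyl or an amine on the same aromatic carbon would lower the number as bromo does, on either core, and so whether the step belongs to bromo alone. They also leave open which part of the difference between the core of compound 1 and the core of compound 3 goes with the larger step, as no pair shown changes one part of that difference at a time.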